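Adding a Methoxy Group to the Phenyl Ring

This account rests on a few compounds, and the source may have more. Where it says the series, first, only, none or still open, it means among the compounds named here.

Compound 1 `COc1ccc(C(=O)N2N=C(c3ccccc3)CC2c2cn(C)c3ccccc23)cn1`: 3040 nM
Compound 2 `COc1cc(C2=NN(C(=O)c3cccnc3)C(c3cn(C)c4ccc(Br)cc34)C2)cc(OC)c1OC`: > 10000 nM
Compound 3 `COc1ccc2c(c1)c(C1CC(c3ccccc3)=NN1C(=O)c1ccc(OC)nc1)cn2C`: 1110 nM

In a functional assay on A549 cells (Homo sapiens) for inhibition, read by MTT assay, with a stated time of 48 h (on this read-out higher numbers stand for weaker inhibition of growth and lower numbers for stronger inhibition of growth), compound 3 has the lower of the two exact numbers, 1110 nM. The entry for compound 2 is a limit and not an exact number. Compound 4 `COc1cccc(C2=NN(C(=O)c3ccc(OC)nc3)C(c3cn(C)c4ccc(OC)cc34)C2)c1` differs from compound 3 by methoxy in place of hydrogen on an aromatic carbon, turning phenyl into 3-methoxyphenyl. Among the compounds with values here, the one measured step of this kind, a 2.7-fold lower number from compound 1 to compound 3 (0.44 log units; beyond the scatter), was modest and lay elsewhere in the molecule, so it is only a loose guide. A change within the scatter, or a slightly lower number, is therefore expected in this assay. The estimated change is a 1.2-fold lower number from compound 3 to compound 4 (0.09 log units; within the scatter). For compound 4 the expected value is 900 nM, with an estimated range of 300 nM to 3000 nM.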

Compound 4, concentration for 50% growth inhibition: 470 nM
For compound 4 the middle estimate is 1.9-fold (0.28 log units) above the measured one; the range from low to high includes it.
By their numbers in this assay, from the lowest: compound 4; then compound 3; then compound 1. At a limit, above all of these: compound 2.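

On the phenyl ring, a place the earlier step did not touch, turning phenyl into 3-methoxyphenyl gives in this assay a real gain: a 2.4-fold lower number from compound 3 to compound 4 (0.37 log units; beyond the scatter). So a methoxy in place of hydrogen lowers the number at a second site, as it did elsewhere in the molecule in a 2.7-fold lower number from compound 1 to compound 3 (0.44 log units; beyond the scatter), and the two modest steps point the same way. No measurement shown bears on why the number falls. On these data alone, whether an amine, a hydroxyl or a longer chain such as ethoxy at this place would do the same remains open.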